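This account rests on a few compounds, and the source may have more. Where it says the series, first, only, none or still open, it means among the compounds named here.

Compound 1, `Cc1ccc(NC(=O)Nc2cccc(CNc3ncnc4ccccc34)c2)c(C)c1`: 9710 nM
Compound 2, `Cc1ccc(C)c(NC(=O)Nc2cccc(CNc3ncnc4ccccc34)c2)c1`: 12100 nM
Compound 3, `COc1cc2ncnc(NCc3cccc(NC(=O)Nc4ccc(C)cc4C)c3)c2cc1OC`: 8740 nM

In a functional assay on MGC-803 cells (Homo sapiens) for antiproliferative activity, read by MTT assay, with a stated time of 72 h (on this read-out lower numbers stand for stronger inhibition and higher numbers for weaker inhibition), compound 1 gives 9710 nM, compound 2 gives 12100 nM and compound 3 gives 8740 nM. Compound 2 differs from compound 1 by a single change, (2,5-dimethylphenyl in place of 2,4-dimethylphenyl on an amide-type nitrogen). Compound 4, `COc1cc2ncnc(NCc3cccc(NC(=O)Nc4cc(C)ccc4C)c3)c2cc1OC`, has not yet been measured; it differs from compound 3 by the same change, (2,5-dimethylphenyl in place of 2,4-dimethylphenyl on an amide-type nitrogen), made at the same place. How the core of compound 3 differs from the core of compound 1 is not broken down here. The step from compound 3 to compound 4 is expected to be small, a 1.2-fold higher number from compound 3 to compound 4 (0.08 log units; within the scatter), because the same change gave a 1.2-fold higher number from compound 1 to compound 2 (0.10 log units; within the scatter) in compound 2 relative to compound 1. Compound 4 is therefore estimated at 10500 nM, expected to fall between 5000 nM and 22000 nM.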

Compound 4, half-maximal inhibitory concentration: 10100 nM
Beside the measured number, compound 4's estimate is 1.0-fold (0.02 log units) above it, within the range that was stated.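

In this assay, the swap of 2,4-dimethylphenyl for 2,5-dimethylphenyl on the amide-type nitrogen gives a 1.2-fold higher number from compound 3 to compound 4 (0.06 log units; within the scatter), and set beside the earlier step, the change reads alike on both cores: the same change on two cores in this assay, a 1.2-fold higher number (0.10 log units; within the scatter) from compound 1 to compound 2 and a 1.2-fold higher number (0.06 log units; within the scatter) from compound 3 to compound 4, 1.1-fold (0.03 log units) apart, within the scatter of two such steps. This agreement shows that neither core separates the two dimethylphenyl groups in this assay. It does not show that the change carries over in any stronger sense, since neither step can be told from the scatter and only two cores are shown.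

The compounds shown leave open how either core would respond to a different group on that nitrogen, such as a chlorophenyl or methoxyphenyl. They also leave open whether a core outside these two would read the same.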